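This account rests on a few compounds, and the source may have more. Where it says the series, first, only, none or still open, it means among the compounds named here.

Of the compounds shown here, two have so far been measured in a functional assay on MCF7 cells (Homo sapiens) for cytotoxicity, read by MTT assay, with a stated time of 24 h (a lower number here means a stronger inhibitor, a higher number a weaker inhibitor), and their numbers sit close together. Compound 1 `COc1ccc(/C=C2\CN(Cc3cn(Cc4cccc(Cl)c4)nn3)C/C(=C\c3ccc(OC)cc3)C2=O)cc1` shows 99000 nM and compound 2 `Cc1ccc(/C=C2\CN(C(=S)SCc3cn(Cc4ccc(F)cc4)nn3)C/C(=C\c3ccc(C)cc3)C2=O)cc1` shows 81600 nM as its half-maximal inhibitory concentration. The two values lie within the scatter of each other, so compound 2 stands level with compound 1. Compound 3 `Cc1ccc(/C=C2\CN(C(=S)SCc3cn(Cc4cccc(Cl)c4)nn3)C/C(=C\c3ccc(C)cc3)C2=O)cc1` awaits measurement. Its difference from compound 2 reads 3-chlorophenyl in place of 4-fluorophenyl on a saturated chain carbon bound to an aromatic nitrogen and in words it is 3-chlorophenyl in place of 4-fluorophenyl on a saturated chain carbon bound to an aromatic nitrogen. Going by the values given here, no measured pair isolates this change, so the data offer no direct guide to it. The nearest hint is compound 1, which also bears a 3-chlorobenzyl and gives 99000 nM despite differing elsewhere. No step beyond the scatter is therefore expected in this assay in either direction. The estimate means a 1.1-fold lower number from compound 2 to compound 3 (0.04 log units; within the scatter) and that expected step stays within the scatter. Compound 3 is estimated at 75000 nM with 35000 nM to 150000 nM as its expected range.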

Compound 3, half-maximal inhibitory concentration: > 100000 nM
Compound 3: no number, only a limit (the forecaster's own chance of this, stated with the estimate: 10%); at least 1.3-fold (0.12 log units) between middle value and limit.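

In this assay, compound 3 gives > 100000 nM, which is a limit of the assay and not a number. Going by these compounds alone, this is the first measured pair that isolates a change at this position, and placing 3-chlorophenyl in place of 4-fluorophenyl on a saturated chain carbon bound to an aromatic nitrogen gives an at least 1.2-fold higher number from compound 2 to compound 3 (0.08 log units; that floor lies within the scatter). The swap therefore brings no move towards a lower number, while the full size of the step stays unread, and the pair fixes only a floor that does not show a real loss, as the reading of compound 3 ends at a limit: the limit of > 100000 nM in this assay, at which 1 of the 3 values shown sits.

The change replaces the halogen and shifts it on the phenyl ring in a single step, so the pair cannot say which of the two matters, and a 4-chlorophenyl or a 3-fluorophenyl group at this position would separate them. Also open, on these data alone, is whether any group here can reach a clearly lower number in this assay, for instance a phenyl ring carrying an amine or a carboxylic acid, or a longer chain in place of the benzyl group.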